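The source may report more compounds than this note shows. Statements on the series, on what has been measured and on what is new or still open speak of the compounds shown alone.

Within the data shown here, in a functional assay (plasma) for inhibition, with Oryctolagus cuniculus as the target (on this read-out lower numbers stand for stronger inhibition and higher numbers for weaker inhibition), compound 1 `O=C(O)CCC/C=C\C[C@H]1[C@@H]2CCC(C2)[C@@H]1NS(=O)(=O)c1ccc(C(=O)O)cc1` gives 800000 nM, the only exact number so far. For compound 2 `O=C(O)CCC/C=C\C[C@H]1[C@@H]2CCC(C2)[C@@H]1NC(=O)c1ccccc1`, the reading of > 800000 nM is a limit and not a number. Compound 3 `O=C(O)CCC/C=C\C[C@H]1[C@@H]2CCC(C2)[C@@H]1NS(=O)(=O)c1ccc(O)cc1` is still unmeasured and differs from compound 1 by hydroxy in place of carboxy on an aromatic carbon. Among the measured compounds shown here, no measured step shows what this swap does. Since compound 1 at 800000 nM is very weak, a large step towards stronger inhibition is expected in this assay. The estimated change runs a 160-fold lower number from compound 1 to compound 3 (2.20 log units; beyond the scatter). Compound 3 is expected at 5000 nM, within an estimated range of 100 nM to 200000 nM.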

Compound 3, half-maximal inhibitory concentration: 500 nM
Compound 3: the middle estimate sits 10-fold (1.00 log units) above what was measured; the measured number falls inside the stated range.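

On this aromatic carbon, para to a large group, one swap of 4-carboxyphenyl to 4-hydroxyphenyl changes the reading greatly: in this assay, the step is a 1600-fold lower number from compound 1 to compound 3 (3.20 log units; beyond the scatter). Among these compounds, this is the first readable step, and it shows that this single position has a strong hold on inhibition, with the rest of the structure unchanged. Compound 2 offers only a limit, not a number: the limit of > 800000 nM in this assay, at which 1 of the 3 values shown sits.

Going by these compounds, whether the step comes from the hydroxy arriving or the carboxy leaving stays open. So does how a methoxy group or an amine on that same aromatic carbon would read.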